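The source may report more compounds than this note shows. Statements on the series, on what has been measured and on what is new or still open speak of the compounds shown alone.

Working notes on the antiproliferative series. Among the measured compounds shown here, compound 1 `CC/C=C/C(=O)Nc1cc2c(N3CCCc4ccccc43)ncnc2cc1OC` gives 2870 nM in a functional assay on MCF7 cells (Homo sapiens) for antiproliferative activity, read by MTT assay, with a stated time of 72 h (a higher number here means a weaker inhibitor, a lower number a stronger inhibitor), the second highest of the three numbers so far. Compound 2 `CC/C=C/C(=O)Nc1cc2c(N3CCCc4ccccc43)ncnc2cc1O[C@@H]1CCOC1` gives 14400 nM, and compound 3 `COc1cc2ncnc(N3CCc4ccccc43)c2cc1NC(=O)/C=C/CN1CCCCC1` gives 1680 nM, the last within the scatter of compound 1. For the measured compounds named here, the only single-point step measured, a 5.0-fold higher number from compound 1 to compound 2 (0.70 log units; beyond the scatter), concerns the ether on the aromatic ring, not the amide chain, and so does not bear directly on the change to compound 4 `COc1cc2ncnc(N3CCCc4ccccc43)c2cc1NC(=O)/C=C/CN1CCCC1`, which is pyrrolidin-1-yl in place of methyl on a saturated chain carbon bound to a double-bonded chain carbon. Compound 3, which carries a related amine on the same chain but differs from compound 1 in two places, gives the only hint. The expected step of a 1.9-fold lower number from compound 1 to compound 4 (0.28 log units; within the scatter) is therefore small, toward a lower number. Compound 4 is expected at 1500 nM, within 500 nM to 4500 nM.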

Compound 4, half-maximal inhibitory concentration: 3190 nM
For compound 4 the middle estimate is 2.1-fold (0.33 log units) below the measured one; the range from low to high includes it.
By their numbers in this assay, from the lowest: compounds 3, 1 and 4 (each within the scatter of the next); then compound 2.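

In this assay, the chain carbon takes pyrrolidin-1-yl in place of methyl with a 1.1-fold higher number from compound 1 to compound 4 (0.05 log units; within the scatter) and thus no readable change, so adding a five-membered ring and a hydrogen-bond acceptor here leaves the number in place. Among the compounds shown here, the change at the aromatic ether, a 5.0-fold higher number from compound 1 to compound 2 (0.70 log units; beyond the scatter), is the only step so far beyond the scatter. No measurement shown gives a reason for the flat step at the chain.

Open, from the compounds shown here alone, is whether dimethylamino, a carboxylic acid or a longer chain at this place would also leave the number unchanged. Also open, going by these compounds, is whether pyrrolidin-1-yl behaves the same with oxolan-3-yl on the ether oxygen.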